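Bromo to chloro swap on the anilino ring of compound 2

The source may report more compounds than this note shows. Statements on the series, on what has been measured and on what is new or still open speak of the compounds shown alone.

Three members of this series have been run in a functional assay on B16-F10 cells (Mus musculus) for antiproliferative activity, read by WST assay, with a stated time of 48 h; on this read-out lower numbers stand for stronger inhibition and higher numbers for weaker inhibition. Compound 1 `Clc1cccc(Nc2ncnc3ccc(NCc4ccc5c(c4)OCCO5)cc23)c1` gives 16.3 ug/mL. Compound 2 `Brc1cccc(Nc2ncnc3ccc(NCc4ccc5c(c4)OCCCO5)cc23)c1` gives 1.99 ug/mL, the lowest of the three numbers, with compound 1 standing higher and compound 3 `Brc1cccc(Nc2ncnc3ccc(NCc4ccc5c(c4)OCCCCO5)cc23)c1`, at 20.6 ug/mL, higher still, both gaps beyond the scatter. Compound 1 and compound 2 differ in two places, so their values alone do not separate the share of either change.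

The next compound, compound 4 `Clc1cccc(Nc2ncnc3ccc(NCc4ccc5c(c4)OCCCO5)cc23)c1`, keeps the core and chain of compound 2 and changes one group: chloro in place of bromo on an aromatic carbon. Within the data shown here, no measured pair in the set isolates this exchange. Among the measured compounds shown here, compound 1, the only chloro-bearing member, carries a weaker number than compound 2, but its chain differs too. For compound 4 a moderate step toward a higher number is expected, a 2.3-fold higher number from compound 2 to compound 4 (0.35 log units; beyond the scatter), possibly just beyond the scatter. Compound 4 is estimated at 4.5 ug/mL, within 1.5 ug/mL to 14 ug/mL.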

Compound 4, half-maximal inhibitory concentration: 2.14 ug/mL
Compound 4: middle estimate off by 2.1-fold (0.32 log units), on the high side, and the stated range covers the measured number.
By their numbers in this assay, from the lowest: compounds 2 and 4 (each within the scatter of the next); then compounds 1 and 3 (each within the scatter of the next).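

In this assay, among these compounds, this is the first pair to isolate the halogen on the anilino ring, and a 1.1-fold higher number from compound 2 to compound 4 (0.03 log units; within the scatter) means that bromo and chloro cannot be told apart at this position when the rest of compound 2 is kept. Compound 1 and compound 4 both carry chloro and differ in one other place, with compound 1 at 16.3 ug/mL and compound 4 at 2.14 ug/mL, so these printed values give the first view of that other place without a halogen exchange alongside it. No measurement available here accounts for the two halogens reading alike.

Going by these compounds, whether the same match holds with the chain of compound 1 or compound 3 remains open. Also open, on these data alone, is how a fluoro, methoxy or nitrile group would read at this position of the anilino ring.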